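The source may report more compounds than this note shows. Statements on the series, on what has been measured and on what is new or still open speak of the compounds shown alone.

Within the data shown here, compound 1, with the structure `O=C1C(=O)N(CCCCn2cc(COc3cc(=O)oc4ccccc34)nn2)c2ccc(F)cc21`, is one of three compounds measured so far in a functional assay on HCT-116 cells (Homo sapiens) for inhibition, read by sulforhodamine B assay, with a stated time of 48 h, tested at 50 uM; a higher number here means more inhibition of growth at the concentration tested, a lower number less inhibition of growth. In this assay compound 1 gives 67%. Its companions share the same core and differ in the halogen on the fused ring and in the length of the chain that joins the two halves. Compound 3, `O=C1C(=O)N(CCCn2cc(COc3cc(=O)oc4ccccc34)nn2)c2ccc(Cl)cc21`, gives 68%, a number within the usual scatter of what compound 1 shows, so the two cannot be told apart on these data. Compound 2, `O=C1C(=O)N(CCCCCn2cc(COc3cc(=O)oc4ccccc34)nn2)c2ccc(Br)cc21`, gives 43%, which lies below compound 1 by more than the scatter.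

The next compound, compound 4 with the structure `O=C1C(=O)N(CCCCn2cc(COc3cc(=O)oc4ccccc34)nn2)c2ccccc21`, differs from compound 1 in a single place: hydrogen in place of fluoro on an aromatic carbon. Among the measured compounds shown here, no measured pair shows what this change does on its own. With compound 1 at 67% as the only anchor, the step of a number 9 percentage points lower from compound 1 to compound 4 (within the scatter) is expected to be small and downward, and may not exceed the scatter. Compound 4 is therefore estimated to give 58% in this assay, with a range from 36% to 78%.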

Compound 4, percent growth inhibition at one concentration: 72%
Compound 4: middle estimate off by 14 percentage points, on the low side, and the stated range covers the measured number.
By their numbers in this assay, from the lowest: compound 2; then compounds 1, 3 and 4 (each within the scatter of the next).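

With the rest of the molecule held fixed, exchanging fluoro for hydrogen on this aromatic carbon gives in this assay a clean single-place comparison: a number 5 percentage points higher from compound 1 to compound 4 (within the scatter). The fluoro is therefore not required for the growth inhibition seen here, as compound 4, with no halogen on this ring, cannot be told apart from compound 1. Nothing available explains this result at the level of mechanism.

The compounds shown leave open whether a different group on this carbon, such as a methoxy group or an amine, would shift the number beyond the scatter. They also leave open whether the lower number of compound 2 comes from its bromo or its longer chain, since compound 2 differs from compound 1 in both places.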